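Swapping Methyl for Trifluoromethyl Ortho to the Amide

A few compounds are considered here, and "the series" means these few. Any claim that something is new, unique, unknown or untested is made for them only; others in the source may bear on it.

Of the compounds shown here, three built on a shared core have been tested in a functional assay on HEK293 cells for agonist activity at Glucose-dependent insulinotropic receptor (Homo sapiens), read by HTRF and cAMP accumulation, with a stated time of 30 min; a lower number here means that less compound is needed, a higher number that more compound is needed for the effect. Compound 1, `CCNC(=O)c1cc(F)c(-c2cc3nnn(C4CCN(c5ncc(CC)cn5)CC4)c3cn2)cc1F`, gives 2 nM. Compound 2, `CCNC(=O)c1ccc(-c2cc3nnn(C4CCN(c5ncc(CC)cn5)CC4)c3cn2)c(Cl)c1`, gives 13 nM. Compound 3, `CCNC(=O)c1ccc(-c2cc3nnn(C4CCN(c5ncc(CC)cn5)CC4)c3cn2)cc1C`, gives 18 nM. Among these three numbers compound 3 stands highest; its gap to compound 2 lies within the usual scatter, so those two cannot be ordered, while its gap to compound 1 lies beyond the scatter, so compound 1 clearly needs less compound than compound 3.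

Compound 4, `CCNC(=O)c1ccc(-c2cc3nnn(C4CCN(c5ncc(CC)cn5)CC4)c3cn2)cc1C(F)(F)F`, has not yet been measured. It differs from compound 3 in a single place: trifluoromethyl in place of methyl on an aromatic carbon. Among the measured compounds shown here, no pair of measured compounds shows this same exchange, so there is no direct precedent for the size of the move. What the set does show is that compound 2 and compound 3 sit within the scatter of each other, whereas compound 1 sits well apart from compound 3. With nothing pointing firmly either way, the step from compound 3 to compound 4 is expected to be a 1.4-fold higher number from compound 3 to compound 4 (0.14 log units; within the scatter), a modest shift that may well stay inside the scatter. Compound 4 is therefore estimated at 25 nM, with a likely range from 8 nM to 80 nM.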

Compound 4, half-maximal effective concentration in the Glucose-dependent insulinotropic receptor assay: 39 nM
Compound 4: the middle estimate sits 1.6-fold (0.19 log units) below what was measured; the range from low to high includes it.
By their numbers in the Glucose-dependent insulinotropic receptor assay, from the lowest: compound 1; then compounds 2 and 3 (each within the scatter of the next); then compound 4.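

Among the compounds shown here, the exchange of methyl for trifluoromethyl, on an aromatic carbon ortho to an ethylcarbamoyl group, is the first change in this set confined to a single place, so its effect can be read directly. In the Glucose-dependent insulinotropic receptor assay it brings a 2.2-fold higher number from compound 3 to compound 4 (0.34 log units; beyond the scatter), which shows that this position is not indifferent to the group it carries, even though the step is modest. The same exchange also lowers solubility in a physicochemical assay for solubility, read by HPLC, in phosphate buffer, measured as thermodynamic solubility, with a stated time of 24 h, at pH 6.8 (a higher number here means a more soluble compound, a lower number a less soluble compound), so trifluoromethyl compares unfavourably with methyl on both read-outs at this position: the measured solubility of compound 3, 1790 nM, and of compound 4, 510 nM, a 3.5-fold lower number (0.55 log units; beyond the scatter) In the physicochemical assay compound 3 gives 1790 nM and compound 4 gives 510 nM.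

On these data alone, with only these two groups compared on this carbon, it remains open what a nitrile, a methoxy group or a plain hydrogen there would do to either number. A single step also cannot tell whether the two read-outs generally move together at this position, or whether the same exchange on another carbon of this ring would give a similar result.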